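Swapping Bromo for Chloro on a Thiourea Inhibitor

The source may report more compounds than this note shows. Statements on the series, on what has been measured and on what is new or still open speak of the compounds shown alone.

In an assay for inhibition of epoxide hydrolase 1 (Homo sapiens), read by fluorescence, using microsomes (on this read-out lower numbers stand for stronger inhibition and higher numbers for weaker inhibition), compound 3 `CC(=O)NC(=S)Nc1ccc(Br)cc1` gives 1640 nM, the lowest of the three numbers shown. Compound 2 `CC(=O)NC(=S)Nc1ccccc1` gives 2350 nM, and the step of a 1.4-fold lower number from compound 2 to compound 3 (0.16 log units; within the scatter) lies within the scatter. Compound 1 `O=C(NC(=S)Nc1ccc(Br)cc1)c1ccccc1` gives 3440 nM, and the step of a 2.1-fold lower number from compound 1 to compound 3 (0.32 log units; beyond the scatter) is modest but beyond the scatter. Compound 4 `CC(=O)NC(=S)Nc1ccc(Cl)cc1` differs from compound 3 by chloro in place of bromo on an aromatic carbon. Going by the values given here, no measured step replaces bromo by chloro; the only step that touches this position, a 1.4-fold lower number from compound 2 to compound 3 (0.16 log units; within the scatter), adds bromo where hydrogen stood and stays within the scatter. A step within the scatter is therefore expected here: a 1.1-fold higher number from compound 3 to compound 4 (0.04 log units; within the scatter). Compound 4 is expected to give about 1800 nM, somewhere between 900 nM and 3600 nM.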

Compound 4, half-maximal inhibitory concentration: 2210 nM
Compound 4: middle estimate off by 1.2-fold (0.09 log units), on the low side; the measured number falls inside the stated range.
By their numbers in this assay, from the lowest: compounds 3, 4, 2 and 1 (each within the scatter of the next, the first and the last beyond it).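

Chloro in place of bromo on this aromatic carbon leaves the number within the scatter in this assay (a 1.3-fold higher number from compound 3 to compound 4 (0.13 log units; within the scatter)), so the two halogens cannot be told apart here. Chloro in place of hydrogen also stays within the scatter (a 1.1-fold lower number from compound 2 to compound 4 (0.03 log units; within the scatter)), so neither halogen has yet shown an effect at this position that repeat measurements could not produce alone. Nothing available explains these results. Still open, from the compounds shown here alone, is whether an amine or a carboxylic acid on this aromatic carbon would move the number beyond the scatter. A longer chain in place of the methyl on the carbonyl carbon is equally untested among the compounds shown.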